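This account rests on a few compounds, and the source may have more. Where it says the series, first, only, none or still open, it means among the compounds named here.

Compound 2 `CC[C@@H]1/C=C(\C)C[C@H](C)C[C@H](OC)[C@H]2O[C@@](O)(C(=O)C(=O)N3CCCC[C@H]3C(=O)O[C@H](/C(C)=C/[C@@H]3CC[C@@H](O)[C@H](Oc4ccc(OC)cc4)C3)[C@H](C)[C@@H](O)CC1=O)[C@H](C)C[C@@H]2OC` and compound 1 `CC[C@@H]1/C=C(\C)C[C@H](C)C[C@H](OC)[C@H]2O[C@@](O)(C(=O)C(=O)N3CCCC[C@H]3C(=O)O[C@H](/C(C)=C/[C@@H]3CC[C@@H](O)[C@H](Oc4ccc(O)cc4)C3)[C@H](C)[C@@H](O)CC1=O)[C@H](C)C[C@@H]2OC` share one core and differ only in that (hydrogen in place of methyl on an oxygen on an aromatic ring). In a functional assay on cells for inhibition, with Murine T-cell line (Mus musculus) as the target (on this read-out higher numbers stand for weaker inhibition and lower numbers for stronger inhibition), compound 2 gives 0.9 nM, and compound 1 gives 0.9 nM; the step reads no change at the digits printed from compound 2 to compound 1 (within the scatter). Compound 3 `CC[C@@H]1/C=C(\C)C[C@H](C)C[C@H](OC)[C@H]2O[C@@](O)(C(=O)C(=O)N3CCCC[C@H]3C(=O)O[C@H](/C(C)=C/[C@@H]3CC[C@@H](Oc4ccc(OC)cc4)[C@H](O)C3)[C@H](C)[C@@H](O)CC1=O)[C@H](C)C[C@@H]2OC` has the same atoms as compound 2 joined differently; the difference between the two cores is not broken down here. In this assay compound 3 gives 1.2 nM, within the scatter of the other two values. Compound 4 `CC[C@@H]1/C=C(\C)C[C@H](C)C[C@H](OC)[C@H]2O[C@@](O)(C(=O)C(=O)N3CCCC[C@H]3C(=O)O[C@H](/C(C)=C/[C@@H]3CC[C@@H](Oc4ccc(O)cc4)[C@H](O)C3)[C@H](C)[C@@H](O)CC1=O)[C@H](C)C[C@@H]2OC` carries the same change as compound 1 does against compound 2: hydrogen in place of methyl on an oxygen on an aromatic ring, at a place described in the same words. The step of no change at the digits printed from compound 3 to compound 4 (within the scatter) is expected for this change, resting on the earlier step of no change at the digits printed from compound 2 to compound 1 (within the scatter). Compound 4 is accordingly estimated at 1.2 nM in this assay, with a range from 0.6 nM to 2.4 nM.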

Compound 4, half-maximal inhibitory concentration: 1.6 nM
For compound 4 the middle estimate is 1.3-fold (0.12 log units) below the measured one; the range from low to high includes it.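

In this assay, going from 4-methoxyphenoxy to 4-hydroxyphenoxy gives a 1.3-fold higher number from compound 3 to compound 4 (0.12 log units; within the scatter). Set beside the earlier step, the change carries from one core to the other with no difference that can be told from scatter: the same change on two cores in this assay, no change at the digits printed (within the scatter) from compound 2 to compound 1 and a 1.3-fold higher number (0.12 log units; within the scatter) from compound 3 to compound 4, 1.3-fold (0.12 log units) apart, within the scatter of two such steps This shows only that methoxy to hydroxy left the read-out within the scatter on these two cores; it does not show that the change has an effect of its own, nor how it would behave on a third core.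

Open, on these data alone, is what a longer chain such as ethoxy, an amine or a carboxylic acid would do in place of the hydroxy on this aromatic ring. Also open, as far as these compounds go, is whether the same picture holds in any other read-out.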